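Swapping a Bromophenyl for a Methylphenyl: Cytotoxicity Outlook

This account rests on a few compounds, and the source may have more. Where it says the series, first, only, none or still open, it means among the compounds named here.

Compound 1 `COC(=O)c1ccc(NCc2cncn2Cc2ccccc2Br)cc1-c1ccccc1`: 10000 nM
Compound 2 `Clc1ccc(Cn2cncc2CNc2cccc(-c3ccccc3)c2)cc1`: 10000 nM

Of the compounds shown here, two have been tested in a toxicity assay on NIH3T3 cells (Mus musculus) for cytotoxicity, read by resazurin assay; a higher number here means that more compound is needed for the effect, a lower number that less compound is needed. Compound 1 gives 10000 nM, and compound 2 gives 10000 nM, so compound 1 sits level with compound 2, within the usual scatter. Compound 3 `COC(=O)c1ccc(NCc2cncn2Cc2ccc(C)cc2)cc1-c1ccccc1` has not yet been measured in this assay. It differs from compound 1 in one place: 4-methylphenyl in place of 2-bromophenyl on a saturated chain carbon bound to an aromatic nitrogen. Among the measured compounds shown here, with no measured step between compounds to lean on, the expected step of no change at the digits printed from compound 1 to compound 3 (within the scatter) is none beyond the scatter. Compound 3 is therefore expected to give about 10000 nM in this assay, within a range from 5000 nM to 20000 nM.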

Compound 3, half-maximal effective concentration: 50000 nM
Estimate against measurement, compound 3: 5.0-fold (0.70 log units) below; measured number outside the range, above it.
By their numbers in this assay, from the lowest: compounds 1 and 2 (each within the scatter of the next); then compound 3.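

In this assay, 4-methylphenyl in place of 2-bromophenyl on a saturated chain carbon bound to an aromatic nitrogen gives a 5.0-fold higher number from compound 1 to compound 3 (0.70 log units; beyond the scatter), so the read-out does respond to what sits at this position. The change swaps both the group on the phenyl ring and its place there, and nothing measured here explains the step.

The compounds shown leave open whether the bromine or the methyl matters more, which 2-methylphenyl or 4-bromophenyl could help separate. Going by these compounds, how a phenyl carrying a carboxylic acid would read at this position also remains open.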